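A few compounds are considered here, and "the series" means these few. Any claim that something is new, unique, unknown or untested is made for them only; others in the source may bear on it.

Compound 1, `O=C(O)CCc1ccc(OCc2ccccc2Br)cc1`, gives 99% in a functional assay on 1321-N1 cells for agonist activity at Free fatty acid receptor 1 (Homo sapiens), read by calcium flux; a higher number here means a larger maximal response, a lower number a smaller maximal response.
Compound 2, `O=C(O)CCc1ccc(NCc2cccc(Br)c2)cc1`, gives 110% in this assay.

Compound 2 stands at the top of these two numbers. Among the measured compounds shown here, its nearest neighbour is compound 1, whose largest response lies lower by a gap that is beyond the usual scatter of this assay, so compound 2 is the stronger of the two on the data in hand; with only two measured compounds, nothing further can be said about a pattern.

The next compound, compound 3, is `Cc1ccc(-c2cccc(CNc3ccc(CCC(=O)O)cc3)c2)cc1`. It departs from compound 2 in one place: 4-methylphenyl in place of bromo on an aromatic carbon. For the measured compounds named here, no measured pair shares this kind of change, so there is no measured step to lean on. Since the read-out is a maximal response and compound 2 already gives a full-scale value, the expectation is that the step of a number 5 percentage points lower from compound 2 to compound 3 (within the scatter) will stay within the scatter, with no clear direction. Compound 3 is therefore estimated at 105%, with a range from 85% to 125%.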

Compound 3, largest response reached (reported as efficacy), in percent of the reference or control that the assay uses: 92%
Compound 3: middle estimate off by 13 percentage points, on the high side; the range from low to high includes it.
By their numbers in this assay, from the lowest: compounds 3 and 1 (each within the scatter of the next); then compound 2.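

Among the compounds shown here, replacing bromo with 4-methylphenyl on this aromatic carbon gives a number 18 percentage points lower from compound 2 to compound 3 (beyond the scatter) in this assay, a modest step, and it is the first measured change at this position. The position accepts a group of 7 heavy atoms with an added six-membered aromatic ring in place of a single bromine, and compound 3 still gives 92% in this assay as its maximal response, yet the loss from compound 2 shows that the response is not indifferent to this exchange. Nothing available accounts for the step, and this single pair cannot establish a trend for the position.

The compounds shown leave open whether the step comes from the added ring itself or from its methyl group, a question that plain phenyl, 4-chlorophenyl or 4-methoxyphenyl on the same carbon would begin to address. They also leave open whether a small group such as chloro or methoxy would behave like bromo here, and whether the same exchange would have a similar effect on the core of compound 1.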